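The source may report more compounds than this note shows. Statements on the series, on what has been measured and on what is new or still open speak of the compounds shown alone.

Three related compounds have been tested in an ADME assay on HaCaT cells (Homo sapiens) for cytotoxicity, read by MTT assay, with a stated time of 48 h; a lower number here means a stronger inhibitor, a higher number a weaker inhibitor. Within the data shown here, compound 3 `FC(F)(F)c1ccc2[nH]c(-c3cn(-c4ccccc4)nc3-c3ccc(Cl)cc3)nc2c1` gives 41800 nM, the only actual number among them. Compound 1 `O=C(OCc1ccccc1)c1ccc2[nH]c(-c3cn(-c4ccccc4)nc3-c3ccc(F)cc3)nc2c1` reads > 50000 nM, which is a limit and not a number. Compound 2 `Fc1ccc2[nH]c(-c3cn(-c4ccccc4)nc3-c3ccc(Cl)cc3)nc2c1` reads > 50000 nM, which is also a limit.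

The next compound is compound 4 `O=C(OCc1ccccc1)c1ccc2[nH]c(-c3cn(-c4ccccc4)nc3-c3ccc(Cl)cc3)nc2c1`, and its change from compound 3 is benzyloxycarbonyl in place of trifluoromethyl on an aromatic carbon. Put simply, benzyloxycarbonyl stands in place of trifluoromethyl on an aromatic carbon, so a larger group enters.

Among the measured compounds shown here, only one measured step bears on this directly: an at least 1.1-fold lower number from compound 2 to compound 3 (0.07 log units; that floor lies within the scatter). That step exchanges fluoro for trifluoromethyl, so it involves the leaving group but not the entering one. The rest of the evidence is the limit of > 50000 nM in this assay, at which 2 of the 3 values shown sit. Compound 1 also carries benzyloxycarbonyl, and its reading of > 50000 nM is a limit.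

Taken together, these results point to little cell toxicity in this assay for compound 4, with no step beyond the usual scatter expected. The estimated change is a 1.1-fold higher number from compound 3 to compound 4 (0.03 log units; within the scatter). For compound 4 the expected value is 45000 nM, with an estimated range from 22000 nM to 75000 nM, and the assay may well report only a limit.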

Compound 4, half-maximal inhibitory concentration: > 50000 nM
Compound 4 was reported as a limit; the forecaster's own chance of this, stated with the estimate: 55%; middle value at least 1.1-fold (0.04 log units) from the limit.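

In this assay, from the compounds shown here alone, putting benzyloxycarbonyl, a much larger group with its own aromatic ring, in place of trifluoromethyl gives an at least 1.1-fold higher number from compound 3 to compound 4 (0.07 log units; that floor lies within the scatter), so this swap at this position shows only a floor, and the true size of the step stays unknown. Benzyloxycarbonyl at this position now appears alongside both chloro and fluoro, in compound 4 and compound 1, but the steps from compound 1 and from compound 2 to compound 4 cannot be read, as both ends of each are limits. Only compound 3 gives an actual number, and the other compounds share a single reading: the limit of > 50000 nM in this assay, at which 3 of the 4 values shown sit.

The compounds shown leave open how far each limit lies from the real value, so they cannot settle whether fluoro, trifluoromethyl or benzyloxycarbonyl at this position truly differ in this cell test. Going by these compounds, it also remains open whether an amine or a carboxylic acid on this aromatic carbon would bring the number clearly down.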